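The compounds below may be only part of what the source reports. "The series", "measured", "known", "first", "only" and "open" are said of these compounds alone.

Measured so far:
Compound 1 `Nc1nc(-c2ccco2)nc2sc(CN3CC=CCC3)cc12`: 150 nM
Compound 2 `Nc1nc(-c2ccco2)nc2sc(CN3CCC(F)CC3)cc12`: 740 nM

In an assay on CHO-K1 cells for antagonist activity at adenosine receptor A1 (Homo sapiens), read by a beta-galactosidase reporter, with stated times of 15 min and 6 h (a higher number here means a weaker inhibitor, a lower number a stronger inhibitor), compound 1 gives 150 nM and compound 2 gives 740 nM, the higher of the two numbers. For the measured compounds named here, the only measured step, a 4.9-fold higher number from compound 1 to compound 2 (0.69 log units; beyond the scatter), alters the saturated ring, not the aromatic group that changes next. Compound 3 `N#Cc1cccc(-c2nc(N)c3cc(CN4CCC(F)CC4)sc3n2)c1` differs from compound 2 by 3-cyanophenyl in place of furan-2-yl on an aromatic carbon. Going by the values given here, no measured step touches this position, so nothing here points to a direction. The expected step is therefore no change at the digits printed from compound 2 to compound 3 (within the scatter), nothing beyond the scatter, though with a wide range. Compound 3 is estimated at 740 nM, between 200 nM and 2800 nM.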

Compound 3, inhibition constant: 2950 nM
Beside the measured number, compound 3's estimate is 4.0-fold (0.60 log units) below it, and the stated range ends below it.
By their numbers in this assay, from the lowest: compound 1; then compound 2; then compound 3.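

The aromatic group on the carbon between two ring nitrogen atoms matters in this assay for this series: 3-cyanophenyl in place of furan-2-yl gives a weaker inhibitor (a 4.0-fold higher number from compound 2 to compound 3 (0.60 log units; beyond the scatter)). This position, like the saturated ring, can therefore move the number beyond the scatter. Nothing measured here explains the shift.

As far as these compounds go, it remains open whether the phenyl ring or its nitrile goes with this loss, a question that a plain phenyl group at this position would help to settle. From the compounds shown here alone, whether the step would be similar with the unsaturated ring of compound 1 also remains open.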